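Compound 3 in the BJ cell cytotoxicity read-out

The source may report more compounds than this note shows. Statements on the series, on what has been measured and on what is new or still open speak of the compounds shown alone.

Compound 1 `Cc1cc(NC(=O)Nc2ccc(C(C)(C)C)cc2)c2ccccc2n1` measures 20000 nM as a number
Compound 2 `Cc1ccc(NC(=O)Nc2cc(C)nc3ccccc23)cc1` measures > 25000 nM as a limit

Both values come from an ADME assay on BJ cells (Homo sapiens) for cytotoxicity, with a stated time of 72 h (on this read-out lower numbers stand for an effect already at smaller amounts and higher numbers for an effect only at larger amounts of compound), where compound 2 gives > 25000 nM as a limit of the assay and not as a number. Compound 3 `COC(=O)c1ccc(NC(=O)Nc2cc(C)nc3ccccc23)cc1` has not yet been measured. It differs from compound 2 by one change, methoxycarbonyl in place of methyl on an aromatic carbon, para to a large group methoxycarbonyl in place of methyl on an aromatic carbon on the shared core. Among the measured compounds shown here, one measured step bears on this, an at least 1.2-fold higher number from compound 1 to compound 2 (0.09 log units; that floor lies within the scatter) and it also exchanges a group on an aromatic carbon. Neither measured compound carries methoxycarbonyl, so this guide is thin. No step beyond the scatter is therefore expected in this assay in either direction. The expected size is a number no higher from compound 2 to compound 3 (the limit leaves the size open) on this estimate. Compound 3 is estimated at 25000 nM with a range from 12000 nM to 50000 nM as its likely span.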

Compound 3, half-maximal effective concentration: 21000 nM
Beside the measured number, compound 3's estimate is 1.2-fold (0.08 log units) above it, within the range that was stated.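

At this position, para to a large group, methoxycarbonyl gives a measured number in this assay, and the change from methyl reads as an at least 1.1-fold lower number from compound 2 to compound 3 (0.07 log units; that floor lies within the scatter). That step is only a floor, because compound 2 stands at a limit of the assay and not at a number: the limit of > 25000 nM in this assay, at which 1 of the 3 values shown sits. Compared with tert-butyl on the same aromatic carbon, methoxycarbonyl gives a 1.1-fold higher number from compound 1 to compound 3 (0.02 log units; within the scatter), so this pair, unlike the earlier one, has a number on both sides, and it shows that these two different groups stay within the scatter of each other.

Going by these compounds, how far the true value of compound 2 lies from that of compound 3 remains open. So does whether any group on this carbon can move the number beyond the scatter, for example an amine or a carboxylic acid.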